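Notes on the isopropyl-to-ethyl step in the series

The source may hold more compounds than are shown below. What is called first, only, known or untested is meant among the compounds shown, and "the series" means these compounds.

Measured compounds:
compound 1 `Clc1ccccc1-c1nnc2nnc(N3CCCC3)nn12`: 2660 nM
compound 2 `CC(C)c1nnc2nnc(N3CCCC3)nn12`: 71200 nM
compound 3 `Clc1ccc(-c2nnc3nnc(N4CCCC4)nn23)c(Cl)c1`: 8650 nM

Compound 2 stands highest of the three numbers in a functional assay on HL-60 cells (Homo sapiens) for cytotoxicity, read by MTT assay, with a stated time of 72 h; on this read-out lower numbers stand for stronger inhibition and higher numbers for weaker inhibition: the step of a 27-fold higher number from compound 1 to compound 2 (1.43 log units; beyond the scatter) sets it well apart, and the values of compound 3 and compound 2 also differ beyond the scatter.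

Compound 4 `CCc1nnc2nnc(N3CCCC3)nn12` is not yet measured; it differs from compound 2 by hydrogen in place of methyl on a saturated chain carbon bound to an aromatic carbon and a saturated chain carbon. Neither measured step speaks to a change of this kind: a 27-fold higher number from compound 1 to compound 2 (1.43 log units; beyond the scatter) concerns 2-chlorophenyl exchanged for isopropyl on an aromatic carbon, and a 3.3-fold higher number from compound 1 to compound 3 (0.51 log units; beyond the scatter) concerns chloro in place of hydrogen on an aromatic carbon. Within the data shown here, no step on alkyl size alone is available, so no movement beyond the scatter is expected in this assay. Compound 4 is therefore estimated at 70000 nM, range 25000 nM to 200000 nM, an expected step of a 1.0-fold lower number from compound 2 to compound 4 (0.01 log units; within the scatter).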

Compound 4, half-maximal inhibitory concentration: 47000 nM
Compound 4: middle estimate off by 1.5-fold (0.17 log units), on the high side; the range from low to high includes it.
By their numbers in this assay, from the lowest: compound 1; then compound 3; then compounds 4 and 2 (each within the scatter of the next).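

In this assay, cutting isopropyl back to ethyl on this saturated chain carbon gives a 1.5-fold lower number from compound 2 to compound 4 (0.18 log units; within the scatter); this single change in alkyl size does not separate the two compounds. The exchange of 2-chlorophenyl for alkyl now reads twice, as a 27-fold higher number from compound 1 to compound 2 (1.43 log units; beyond the scatter) and as an 18-fold higher number from compound 1 to compound 4 (1.25 log units; beyond the scatter), so the large gap is not peculiar to isopropyl. No evidence at hand accounts for either step.

Open, as far as these compounds go, is whether methyl, a longer chain such as n-butyl, or an amine on the chain would stay with ethyl and isopropyl. Also open, from the compounds shown here alone, is whether unsubstituted phenyl would stay with compound 1.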